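This account rests on a few compounds, and the source may have more. Where it says the series, first, only, none or still open, it means among the compounds named here.

Compound 1, `CCCCOC(=N)NC(=N)Nc1ccc(Cl)cc1`: 3.32
Compound 2, `CCCCCCCCOC(=N)NC(=N)Nc1ccc(Cl)cc1`: 5.32
Compound 3, `CCCCCCCCCCCCNC(=N)NC(=N)Nc1ccc(Cl)cc1`: 7.13

In a physicochemical assay for lipophilicity, in phosphate buffer, measured as octanol-water partition, at pH 11.5 (on this read-out higher numbers stand for higher lipophilicity and lower numbers for lower lipophilicity), compound 3 gives the highest of the three numbers, beyond the scatter against both compound 2 and compound 1. The difference between the core of compound 3 and that of compound 2 is not broken down here. Compound 1 and compound 2 differ in one place, by hydrogen in place of butyl on a saturated chain carbon, four bonds along the chain from an oxygen on an unsaturated carbon, and this gave a number 2.00 log units lower from compound 2 to compound 1 (beyond the scatter). Compound 4, `CCCCCCCCNC(=N)NC(=N)Nc1ccc(Cl)cc1`, has not yet been measured in this assay; it differs from compound 3 by hydrogen in place of butyl on a saturated chain carbon, eight bonds along the chain from an amine nitrogen. The place differs: in compound 2 the butyl sits four bonds along the chain from an oxygen on an unsaturated carbon, in compound 3 eight bonds along the chain from an amine nitrogen, so this is the same kind of change, not the same. Because the earlier step gave a number 2.00 log units lower from compound 2 to compound 1 (beyond the scatter), a similar step is expected here, namely a number 1.98 log units lower from compound 3 to compound 4 (beyond the scatter). Compound 4 is therefore estimated at 5.15, between 4.7 and 5.6.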

Compound 4, partition coefficient: 5.13
The estimate for compound 4 lay 0.02 log units above the measured number; the range from low to high includes it.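

In this assay hydrogen in place of butyl gave a number 2.00 log units lower from compound 3 to compound 4 (beyond the scatter) on one core and a number 2.00 log units lower from compound 2 to compound 1 (beyond the scatter) on the other, so in these two pairs the change carried from core to core with its size intact. Going by these compounds alone, this rests on only one pair for each core, with the butyl at a different place along the chain in each, so it does not show that the step would hold on a further core or at other chain lengths. Nothing given here explains why the two steps agree.

The compounds shown leave open whether a similar step would appear with a shorter chain such as ethyl on either core. They also leave open what a chain ending in a carboxylic acid or an amine would do to this number.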